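This account rests on a few compounds, and the source may have more. Where it says the series, first, only, none or still open, it means among the compounds named here.

Measured compounds:
- compound 1 `O=c1c2cncn2nc(SCc2cccc(F)c2)n1-c1ccccc1`: 500 nM
- compound 2 `Cn1ncc2c(=O)n(-c3ccccc3)c(OCc3cccc(F)c3)nc21`: 1700 nM

Of the compounds shown here, two have been measured in an assay on isolated protein for inhibition of Retinaldehyde dehydrogenase 3 (Homo sapiens); on this read-out higher numbers stand for weaker inhibition and lower numbers for stronger inhibition. Compound 1 gives 500 nM in this assay. Compound 2 gives 1700 nM in this assay, which is the higher of the two numbers and thus the weaker inhibition; compound 1 and compound 2 differ in their shared core, so no single change links them.

Compound 3 `CC(Oc1nc2c(cnn2C)c(=O)n1-c1ccccc1)c1ccccc1` has not yet been measured. It differs from compound 2 in one place: 1-phenylethyl in place of 3-fluorobenzyl on an oxygen on an aromatic ring. For the measured compounds named here, no pair of measured compounds that differ in just one place is available, so the size of this step cannot be read from the data. The group that leaves and the group that enters are matched in size, each carrying one six-membered aromatic ring of carbon only, and neither brings a donor or an acceptor. On that basis the step from compound 2 to compound 3 is expected to be small, with the change of a 1.5-fold higher number from compound 2 to compound 3 (0.17 log units; within the scatter) likely to fall within or only just beyond the scatter of repeated measurements. Compound 3 is therefore estimated at 2500 nM in this assay, with a range from 800 nM to 8000 nM.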

Compound 3, half-maximal inhibitory concentration: 600 nM
Beside the measured number, compound 3's estimate is 4.2-fold (0.62 log units) above it; the whole stated range lies above it.
By their numbers in this assay, from the lowest: compounds 1 and 3 (each within the scatter of the next); then compound 2.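

In this assay, for the compounds shown here, the group on this oxygen clearly affects the result: 1-phenylethyl in place of 3-fluorobenzyl gives a 2.8-fold lower number from compound 2 to compound 3 (0.45 log units; beyond the scatter), the first step that can be read directly. Each group has the same number of heavy atoms and one six-membered aromatic ring of carbon only, and neither has a hydrogen-bond donor or acceptor, so these shared counts do not settle the number at this position. No available evidence explains the size or direction of this step.

The change removes the fluorine and also alters the carbon joining the ring to the oxygen, so the compounds shown leave open which part of the change matters, a question that a plain benzyl group on the same oxygen could help separate. Also open, from the compounds shown here alone, are how this position would respond to a different kind of group, such as an amine or a carboxylic acid on a longer chain, and whether the same swap would give a similar step on the core of compound 1.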